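From 3,4-dichlorophenyl to 2,3-dimethoxyphenyl on the shared core

The source may hold more compounds than are shown below. What is called first, only, known or untested is meant among the compounds shown, and "the series" means these compounds.

In a functional assay on HOS cells (Homo sapiens) for antiproliferative activity, with a stated time of 72 h (a higher number here means a weaker inhibitor, a lower number a stronger inhibitor), compound 1 `OC[C@H]1O[C@@H](n2cnc3c(NCc4ccc(F)cc4)ncnc32)[C@H](O)[C@@H]1O` gives 13200 nM.

Compound 2 `OC[C@H]1O[C@@H](n2cnc3c(NCc4ccc(Cl)c(Cl)c4)ncnc32)[C@H](O)[C@@H]1O` gives > 166000 nM, which is a limit of the assay and not a number. Among the compounds with values here, the only position known for compound 2 is therefore (the limit of > 166000 nM in this assay, at which 1 of the 2 values shown sits).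

Compound 3 `COc1cccc(CNc2ncnc3c2ncn3[C@@H]2O[C@H](CO)[C@@H](O)[C@H]2O)c1OC` keeps the shared core and differs from compound 2 at a single place: 2,3-dimethoxyphenyl in place of 3,4-dichlorophenyl on a saturated chain carbon bound to a nitrogen on an aromatic ring.

Within the data shown here, one measured step bears on this place, and it is large and beyond the scatter: an at least 12-fold higher number from compound 1 to compound 2 (1.09 log units; beyond the scatter). It shows that exchanging this group alone can shift the number strongly in this assay. Among the measured compounds shown here, no compound with a 2,3-dimethoxyphenyl group has been measured, so the size of the next step remains uncertain. A large step toward a lower number is nevertheless expected, leaving compound 3 nearer to compound 1, with its 13200 nM, though still on the weaker side of it.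

The expected step is an at least 5.5-fold lower number from compound 2 to compound 3 (0.74 log units; beyond the scatter).

The estimate for compound 3 is 30000 nM, with an expected range from 6000 nM to 150000 nM.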

Compound 3, half-maximal inhibitory concentration: > 166000 nM
Compound 3 gave a limit, no number; the forecaster's own chance of this, stated with the estimate: 30%; at least 5.5-fold (0.74 log units) between middle value and limit.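

In this assay, compound 3 ends at a limit of the assay and not at a number, so a 2,3-dimethoxyphenyl group on this chain carbon falls in the same unresolved region as the 3,4-dichlorophenyl group of compound 2: the limit of > 166000 nM in this assay, at which 2 of the 3 values shown sit. Exchanging 4-fluorophenyl for 2,3-dimethoxyphenyl gives an at least 12-fold higher number from compound 1 to compound 3 (1.09 log units; beyond the scatter), so the large shift at this position is no longer tied to the chlorine-bearing group alone and also appears with a methoxy-bearing ring. Of the three groups shown, only 4-fluorophenyl gives a measured number, while the step between the two limits cannot be read, and no order can be given for the dichloro and dimethoxy groups.

On these data alone, both groups that end at the limit carry two ring substituents and the group of compound 1 carries one, so it remains open whether the number of substituents or their identity governs the loss. A plain phenyl, a 4-chlorophenyl or a 4-methoxyphenyl group at the same place would separate these readings, and the shown compounds do not say how far any such group would lie from compound 1.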